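Methoxy to Hydroxy: Expected Lipophilicity of Compound 4

The source may hold more compounds than are shown below. What is called first, only, known or untested is meant among the compounds shown, and "the series" means these compounds.

Of the compounds shown here, three have been measured in a physicochemical assay for lipophilicity, read by HPLC; a higher number here means a more lipophilic compound, a lower number a more polar compound. Compound 1 `COc1cc(/C=C/c2ccc(CO)cc2)ccc1/C=C/c1ccc(CO)cc1` gives 4.99 in this assay. Compound 3 `Oc1cc(/C=C/c2ccc(C(F)(F)F)cc2)ccc1/C=C/c1ccc(C(F)(F)F)cc1` gives 6.18. Compound 2 `COc1cc(/C=C/c2ccc(OC(F)(F)F)cc2)ccc1/C=C/c1ccc(OC(F)(F)F)cc1` gives > 7, and this is a limit of the assay rather than a number. Compound 2 therefore stands at the top of what has been measured, at the limit of > 7 in this assay, at which 1 of the 3 values shown sits. Among the measured compounds shown here, no two of the three compounds differ in only one place, so no measured step between them is available, and nothing can be said about what any single change does on its own.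

Compound 4 `Oc1cc(/C=C/c2ccc(OC(F)(F)F)cc2)ccc1/C=C/c1ccc(OC(F)(F)F)cc1` is not yet measured. It differs from compound 2 in one place: hydrogen in place of methyl on an oxygen on an aromatic ring, or methoxy to hydroxy read one bond further out. With compound 2 only known as a limit, the starting point itself is uncertain. A small downward step is expected, possibly no larger than the scatter; the expected step is a number at least 0.20 log units lower from compound 2 to compound 4 (that floor lies within the scatter). Compound 4 is estimated to give 6.8 in this assay, with a range from 6.3 to 7.3, and it may again come out only as a limit.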

Compound 4, partition coefficient: > 7
Compound 4: a limit, no number; the forecaster's own chance of this, stated with the estimate: 40%; middle value at least 0.20 log units from the limit.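

In this assay compound 4 gives > 7, which is a limit of the assay and not a number. Compound 2 gives > 7, also a limit. No step can be read between compound 2 and compound 4. The compounds shown leave open how large the change from methoxy to hydroxy is in this assay, and in which direction it goes.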